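The compounds below may be only part of what the source reports. "The series", "measured", "known", "first", "only" and "open" are said of these compounds alone.

Measured so far in the series:
- compound 1 `O=Cc1ccc(-c2cn3ccnc3c(-c3ccc4ncn(C5CCCCC5)c4c3)n2)cc1`: 19%
- compound 2 `c1ccc2c(-c3cn4ccnc4c(-c4ccc5ncn(C6CCCCC6)c5c4)n3)cccc2c1`: 36.5%
- compound 3 `Fc1ccccc1-c1cn2ccnc2c(-c2ccc3ncn(C4CCCCC4)c3c2)n1`: 32.6%

In a functional assay on PC-3 cells (Homo sapiens) for inhibition, read by sulforhodamine B assay, with a stated time of 48 h, tested at 10 uM (a higher number here means more inhibition at the concentration tested (going by the name of the read-out), a lower number less inhibition), compound 3 gives 32.6%, the second highest of the three numbers. Its nearest neighbour is compound 2: a number 3.9 percentage points lower from compound 2 to compound 3 (within the scatter), so the two cannot be ordered. Its furthest is compound 1: a number 13.6 percentage points higher from compound 1 to compound 3 (beyond the scatter).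

Compound 4 `c1csc(-c2cn3ccnc3c(-c3ccc4ncn(C5CCCCC5)c4c3)n2)c1` is the next to be measured. The change from compound 3 is thiophen-2-yl in place of 2-fluorophenyl on an aromatic carbon.

For the measured compounds named here, two measured steps bear on this. Both a number 17.5 percentage points higher from compound 1 to compound 2 (beyond the scatter) and a number 13.6 percentage points higher from compound 1 to compound 3 (beyond the scatter) replace 4-formylphenyl with a different aromatic group at the same place, and each gives a modest rise. Between the two groups that lack the formyl, a number 3.9 percentage points lower from compound 2 to compound 3 (within the scatter) stays within the scatter. Compound 4 also carries a plain aromatic ring at this place, without a formyl, so the nearest analogy is the swap from compound 2 to compound 3 rather than the steps from compound 1. The expected step in this assay is therefore one not beyond the scatter: a number 2.6 percentage points lower from compound 3 to compound 4 (within the scatter).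

For compound 4 in this assay the estimate is 30%, with a range from 14% to 46%.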

Compound 4, a percentage reported as inhibition, at one concentration (the size of the read-out at that concentration, not a potency): 49.1%
For compound 4 the middle estimate is 19.1 percentage points below the measured one; the whole stated range lies below it.
By their numbers in this assay, from the lowest: compound 1; then compounds 3 and 2 (each within the scatter of the next); then compound 4.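

In this assay, the group at this position still matters once the formyl is gone: the step is a number 16.5 percentage points higher from compound 3 to compound 4 (beyond the scatter) and a number 12.6 percentage points higher from compound 2 to compound 4 (beyond the scatter), whereas the earlier swap between two formyl-free rings, a number 3.9 percentage points lower from compound 2 to compound 3 (within the scatter), did not leave the scatter. Thiophen-2-yl is the first five-membered aromatic ring with 1 hetero atom at this place, and it puts compound 4 above all three others, the widest step being a number 30.1 percentage points higher from compound 1 to compound 4 (beyond the scatter), so compound 4 has the highest number of the four in this read-out. No measurement at hand explains why this ring gives the higher number.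

The compounds shown do not separate the sulfur atom from the five-membered ring itself, and a furan-2-yl group at this place would bear on that question. On these data alone, how an aminomethyl group or a carboxylic acid on the thiophene would read also stays open, as does whether the rise seen at one concentration in this assay corresponds to any difference in potency.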